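From 3,5-dichlorophenyl to 3,5-dimethoxyphenyl on the shared core

The compounds below may be only part of what the source reports. "The series", "measured", "known", "first", "only" and "open" are said of these compounds alone.

Of the compounds shown here, three on the shared core have been read in an ADME assay on microsomes from liver (Mus musculus) for metabolic stability, read by LC-MS, with a stated time of 1 h, tested at 5 uM; a higher number here means that more of the compound is left, a lower number that less of the compound is left. Compound 1 `Cc1nc(-c2ccccc2)c(C(=O)N2CCN(c3cccc(Cl)c3)CC2)o1`, with a 3-chlorophenyl group, gives 2%. Compound 2 `Cc1nc(-c2ccccc2)c(C(=O)N2CCN(c3cccc(C)c3C)CC2)o1`, with a 2,3-dimethylphenyl group, gives 83.6%. Compound 3 `Cc1nc(-c2ccccc2)c(C(=O)N2CCN(c3cc(Cl)cc(Cl)c3)CC2)o1` gives 43.4%, which places it second of the three and well apart from both others.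

Compound 4 `COc1cc(OC)cc(N2CCN(C(=O)c3oc(C)nc3-c3ccccc3)CC2)c1` has not yet been measured. It carries 3,5-dimethoxyphenyl in place of 3,5-dichlorophenyl on an amine nitrogen in a ring.

All three measured changes at this nitrogen substituent are large: a number 81.6 percentage points higher from compound 1 to compound 2 (beyond the scatter), a number 41.4 percentage points higher from compound 1 to compound 3 (beyond the scatter) and a number 40.2 percentage points lower from compound 2 to compound 3 (beyond the scatter). For the measured compounds named here, a step beyond the scatter is therefore expected here too, although no measured compound carries a methoxy group and the direction remains uncertain. The closest guide is a number 41.4 percentage points higher from compound 1 to compound 3 (beyond the scatter), where chloro replaces hydrogen on an aromatic carbon. Compound 4 has no chloro group, so a lower number is expected, though the size is poorly defined.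

The expected change in this assay is a number 18.4 percentage points lower from compound 3 to compound 4 (beyond the scatter). For compound 4 the estimated value is 25%, with an expected range of 5% to 55%.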

Compound 4, percent of the compound remaining: 0.7%
The estimate for compound 4 lay 24.3 percentage points above the measured number; measured number below the stated range.
By their numbers in this assay, from the lowest: compounds 4 and 1 (each within the scatter of the next); then compound 3; then compound 2.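

In this assay, 3,5-dimethoxyphenyl on the amine nitrogen in a ring gives a number 42.7 percentage points lower from compound 3 to compound 4 (beyond the scatter), and the comparison with the most stable compound gives a number 82.9 percentage points lower from compound 2 to compound 4 (beyond the scatter), so exchanging the chloro groups of 3,5-dichlorophenyl for methoxy groups is enough to produce a large step at this position. The comparison with the 3-chlorophenyl compound gives a number 1.3 percentage points lower from compound 1 to compound 4 (within the scatter), so these two compounds cannot be told apart here, and the higher number of compound 3 cannot be read as a general result of having two groups on the phenyl ring. No available data bear on the reason for these differences.

As far as these compounds go, it remains open whether 3,5-dimethylphenyl on the shared core would read nearer compound 2 or compound 4, which would help separate the contribution of the methyl groups in compound 2 from that of their positions on the ring. From the compounds shown here alone, it also remains open whether 3-methoxyphenyl or 3,5-difluorophenyl would stay as low as compound 4 or rise towards compound 3.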